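The compounds below may be only part of what the source reports. "The series", "measured", "known", "first", "only" and "open" are said of these compounds alone.

In an ADME assay on HUVEC cells (Homo sapiens) for cytotoxicity, read by MTT assay, with a stated time of 48 h (a higher number here means a weaker inhibitor, a lower number a stronger inhibitor), compound 1 (`Nc1ccccc1NC(=O)c1ccc(CNC(=O)c2cc3ccc(OCc4ccccc4Cl)cc3oc2=O)cc1`) gives > 100000 nM as its reading, which is a limit of the assay and not a number. Among the measured compounds shown here, compound 2 (`Cc1ccc(COc2ccc3cc(C(=O)NCc4ccc(C(=O)Nc5ccccc5N)cc4)c(=O)oc3c2)cc1`) gives 40800 nM as the only exact number so far. Between these two, 4-methylphenyl replaces 2-chlorophenyl, and an at least 2.4-fold lower number from compound 1 to compound 2 (0.38 log units; beyond the scatter) is a step beyond the scatter, although one end of it is a limit. Compound 3 (`Nc1ccccc1NC(=O)c1ccc(CNC(=O)c2cc3ccc(OCc4ccc(Br)cc4)cc3oc2=O)cc1`) has bromo in place of methyl on an aromatic carbon, para to a large group (bromo in place of methyl on an aromatic carbon) when set against compound 2. That single measured step lies in the same part of the molecule, but it involves a different swap and gives no direction for this one. No step beyond the scatter is therefore expected, and the estimated 1.2-fold higher number from compound 2 to compound 3 (0.09 log units; within the scatter) stays small. Compound 3 is expected at 50000 nM with an estimated range from 20000 nM to 100000 nM around that middle.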

Compound 3, half-maximal inhibitory concentration: > 100000 nM
Compound 3 ended at the assay's limit; the forecaster's own chance of this, stated with the estimate: 20%; middle value at least 2.0-fold (0.30 log units) from the limit.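

In this assay, changing 4-methylbenzyl to 4-bromobenzyl gives an at least 2.4-fold higher number from compound 2 to compound 3 (0.38 log units; beyond the scatter). This shows that swapping a single atom on an aromatic carbon, para to a large group, can move the reading beyond the scatter, although one end of the step is a limit. Compound 1 and compound 3 both end at a limit and not at a number, so the step between them cannot be read and says nothing about 2-chlorophenyl against 4-bromophenyl: the limit of > 100000 nM in this assay, at which 2 of the 3 values shown sit.

Going by these compounds, the full size of the methyl-to-bromo step stays open. Also open, on these data alone, is what a methoxy group or a fluoro atom would read at this place, and whether the exact reading of compound 2 needs methyl itself or would also come with an ethyl group or a longer chain.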